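Tert-butyl for butyl on the aryl ring, linker held

A few compounds are considered here, and "the series" means these few. Any claim that something is new, unique, unknown or untested is made for them only; others in the source may bear on it.

Compound 1 `CC(C)(C)c1ccc(-c2cc(N3CCC(CNS(N)(=O)=O)CC3)ncn2)cc1` and compound 2 `CCCCc1ccc(-c2cc(N3CCC(CCNS(N)(=O)=O)CC3)ncn2)cc1` share a core and differ in two places. In a functional assay on MCF7 cells (Homo sapiens) for antiproliferative activity, read by sulforhodamine B assay, with a stated time of 48 h (a lower number here means a stronger inhibitor of growth, a higher number a weaker inhibitor of growth), compound 1 gives 19700 nM, and compound 2 gives 11300 nM; the two values sit within the usual scatter of each other, so neither stands apart. Compound 3 `CC(C)(C)c1ccc(-c2cc(N3CCC(CCNS(N)(=O)=O)CC3)ncn2)cc1` is compound 2 with tert-butyl in place of butyl on an aromatic carbon. Going by the values given here, no measured pair shows this change alone, so the step from compound 2 is expected to be small, likely no larger than the scatter, perhaps a slightly higher number, giving an expected 1.3-fold higher number from compound 2 to compound 3 (0.12 log units; within the scatter). Compound 3 is therefore estimated at 15000 nM, with a range from 6000 nM to 40000 nM.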

Compound 3, concentration for 50% growth inhibition: 13100 nM
The estimate for compound 3 lay 1.1-fold (0.06 log units) above the measured number, within the range that was stated.
By their numbers in this assay, from the lowest: compounds 2, 3 and 1 (each within the scatter of the next).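

In this assay the swap of butyl for tert-butyl on the aromatic carbon, with the linker held, gives a 1.2-fold higher number from compound 2 to compound 3 (0.06 log units; within the scatter) and so stays within the scatter; at this position, the two groups cannot be told apart. The chain change alone, (sulfamoylamino)methyl in place of sulfamoylamino, gives a 1.5-fold lower number from compound 1 to compound 3 (0.18 log units; within the scatter) and also stays within the scatter, which separates the two differences that were combined between compound 1 and compound 2. Nothing available explains either result.

Still open, on these data alone, is whether an amine or a carboxylic acid on that aromatic carbon would move the number beyond the scatter. The same question stands for a longer chain leading to the sulfamoylamino group.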